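The source may report more compounds than this note shows. Statements on the series, on what has been measured and on what is new or still open speak of the compounds shown alone.

Of the compounds shown here, three have been measured in an ADME assay on PC-3 cells (Homo sapiens) for cytotoxicity, read by WST assay, tested at 100 uM (a higher number here means more inhibition at the concentration tested (going by the name of the read-out), a lower number less inhibition), so far. Compound 1 `O=C(Nc1ccc(Cl)cn1)C1CCCN(C(=O)c2cc(C(F)(F)F)cc(C(F)(F)F)c2)C1` gives 0% in this assay. Compound 2 `COc1cccc(C(=O)N2CCCC(C(=O)Nc3ccc(Cl)cc3)C2)c1` gives 0% in this assay, level with compound 1 at the digits shown. Compound 3 `O=C(Nc1ccc(Cl)cc1)C1CCCN(C(=O)c2ccc(-c3ccco3)cc2)C1` gives 6% in this assay, a number that differs from compound 2 by an amount within the usual scatter, so no order between these two compounds can be read from the figures. All three numbers thus sit close to the bottom of the read-out.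

The account now turns to compound 4 `CS(=O)(=O)c1cccc(C(=O)N2CCCC(C(=O)Nc3ccc(Cl)cc3)C2)c1`, which has not yet been measured in this assay. It differs from compound 2 in one place: methylsulfonyl in place of methoxy on an aromatic carbon. For the measured compounds named here, no measured pair in this set shows what such a change does to the read-out, so the expectation rests on the small numbers of compounds 1, 2 and 3 alone.

Given the near-zero values seen, the step from compound 2 to compound 4 is expected to be a number 2 percentage points higher from compound 2 to compound 4 (within the scatter), that is, nothing beyond the scatter. Compound 4 is therefore estimated to give about 2% in this assay, with a likely range from 0% to 12%.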

Compound 4, a percentage reported as inhibition, at one concentration (the size of the read-out at that concentration, not a potency): 2%
Compound 4: the middle estimate sits on the measured number at the digits printed; measured number inside the range.
By their numbers in this assay, from the lowest: compounds 1, 2, 4 and 3 (each within the scatter of the next).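

In this assay, for the compounds shown here, the exchange of methoxy for methylsulfonyl on an aromatic carbon, meta to a large group, gives a number 2 percentage points higher from compound 2 to compound 4 (within the scatter) and is the only single-place step in the set. Going by these compounds alone, until now, no pair could show what a change at any one place does to this read-out. Here the larger group, at 4 heavy atoms against 2, and the added hydrogen-bond acceptor leave compound 4 near the bottom of the read-out alongside compound 2, so the number shows no readable shift at the one concentration tested.

On these data alone, whether an amine or a carboxylic acid at this same place would move the number beyond the scatter remains open. Nothing shown here bears on why the read-out stays so low for both compounds.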